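The source may report more compounds than this note shows. Statements on the series, on what has been measured and on what is new or still open speak of the compounds shown alone.

Measured compounds:
compound 1 `COc1ccc(NS(=O)(=O)c2ccc(N3CCNC3=O)cc2)cc1` — 800 nM
compound 2 `CCCCOc1ccc(NS(=O)(=O)c2ccc(N3CCNC3=O)cc2)cc1` — 630 nM
compound 3 `CCCCCCOc1ccc(NS(=O)(=O)c2ccc(N3CCNC3=O)cc2)cc1` — > 1000 nM

In a functional assay on HT-29 cells (Homo sapiens) for antiproliferative activity, read by sulforhodamine B assay, with a stated time of 48 h (on this read-out lower numbers stand for stronger inhibition and higher numbers for weaker inhibition), compound 1 gives 800 nM, the higher of the two numbers in the set. Its nearest neighbour is compound 2, and the step of a 1.3-fold lower number from compound 1 to compound 2 (0.10 log units; within the scatter) stays within the scatter. Compound 3 returns only a limit, (the limit of > 1000 nM in this assay, at which 1 of the 3 values shown sits). The steps of an at least 1.2-fold higher number from compound 1 to compound 3 (0.09 log units; that floor lies within the scatter) and an at least 1.5-fold higher number from compound 2 to compound 3 (0.20 log units; that floor lies within the scatter) are floors that likewise sit within the scatter. All three measured steps vary the chain on the oxygen on the aromatic ring and leave the rest of the shared core of compound 1 untouched.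

Compound 4 `Cc1cc(C)cc(NS(=O)(=O)c2ccc(N3CCNC3=O)cc2)c1` differs from compound 1 by 3,5-dimethylphenyl in place of 4-methoxyphenyl on a sulfonamide nitrogen. Among the measured compounds shown here, none of the measured steps alters this ring, so they bear on the change only indirectly: every variation made so far at this position has stayed within the scatter. No step beyond the scatter is therefore expected in this assay in either direction, which is what the expected step of a 1.1-fold higher number from compound 1 to compound 4 (0.05 log units; within the scatter) expresses. Compound 4 is estimated at 900 nM, with a range from 400 nM to 2500 nM.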

Compound 4, half-maximal inhibitory concentration: 82 nM
Beside the measured number, compound 4's estimate is 11-fold (1.04 log units) above it; the measured number lies below the stated range.
By their numbers in this assay, from the lowest: compound 4; then compounds 2 and 1 (each within the scatter of the next). At a limit, above all of these: compound 3.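

The step of a 9.8-fold lower number from compound 1 to compound 4 (0.99 log units; beyond the scatter) in this assay shows that the sulfonamide nitrogen is a place where a single change moves the number beyond the scatter. Varying the chain on the oxygen of the 4-methoxyphenyl group gave only steps or floors within the scatter, so replacing the whole group reaches something those chain changes did not. The entering and leaving groups each have 8 heavy atoms and one six-membered aromatic ring of carbon only, while 3,5-dimethylphenyl has 0 hydrogen-bond acceptors against 1 for 4-methoxyphenyl, and nothing measured here accounts for the step.

Going by these compounds, it remains open whether the lower number depends on the two methyl groups, on the loss of the methoxy group, or on both; an unsubstituted phenyl ring or a phenyl ring carrying a single methyl group on the sulfonamide nitrogen would help to separate these. Also open, on these data alone, is how far the change tolerates other atoms, such as chlorine in place of the methyl groups, or a longer alkyl chain such as ethyl in their place.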